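The source may hold more compounds than are shown below. What is called first, only, known or untested is meant among the compounds shown, and "the series" means these compounds.

Compound 3 `CC#C[C@@H](Cc1nnn[nH]1)c1ccc(OCc2ccc3sc(F)c(-c4ccccc4C)c3c2)cc1` gives 0.0667 h in an ADME assay on microsomes from liver (Homo sapiens) for metabolic stability (a lower number here means that the compound disappears faster, a higher number that the compound lasts longer), the lowest of the three numbers recorded here. Compound 1 `CC#C[C@@H](Cc1nnn[nH]1)c1ccc(OCc2ccc3sc(F)c(-c4ccc(OCCOC)cc4C)c3c2)cc1` gives 1.95 h and compound 2 `CC#C[C@@H](Cc1nnn[nH]1)c1ccc(OCc2ccc3scc(-c4ccc(OCCC(C)(C)O)cc4C)c3c2)cc1` gives 0.95 h, both well beyond the scatter above compound 3. Going by the values given here, the one measured step, a 29-fold lower number from compound 1 to compound 3 (1.47 log units; beyond the scatter), concerns the 2-methoxyethoxy group and not the halogen.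

Compound 4 `CC#C[C@@H](Cc1nnn[nH]1)c1ccc(OCc2ccc3sc(I)c(-c4ccccc4C)c3c2)cc1` differs from compound 3 in a single place: iodo in place of fluoro on an aromatic carbon. Among the compounds with values here, no measured pair shows a fluoro giving way to an iodo, so the data offer no direct guide to the size or direction of this step in this assay. The expected change is therefore small, a 1.5-fold higher number from compound 3 to compound 4 (0.18 log units; within the scatter), with real uncertainty either way. Compound 4 is estimated at 0.1 h, within a range from 0.03 h to 0.35 h.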

Compound 4, half-life: 0.167 h
Compound 4: the middle estimate sits 1.7-fold (0.22 log units) below what was measured; the measured number falls inside the stated range.
By their numbers in this assay, from the lowest: compound 3; then compound 4; then compound 2; then compound 1.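

The halogen on the aromatic carbon next to the ring sulfur does affect the number in this assay, and swapping fluoro for iodo gives a modest step beyond the scatter (a 2.5-fold higher number from compound 3 to compound 4 (0.40 log units; beyond the scatter)). Going by these compounds alone, this is the first measured change at this position, and the compound with the larger halogen lasts longer here. Nothing available explains this step.

As far as these compounds go, whether a chloro, a bromo or a nitrile at this carbon would land near fluoro or iodo stays open. So does whether a 2-methoxyethoxy group on compound 4 would raise the number as it does on compound 3.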